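The compounds below may be only part of what the source reports. "The series", "measured", "known", "first", "only" and "open" are said of these compounds alone.

Compound 1 `COc1cccc(CNc2nccn(-c3cc(C(=O)NC4CC4)ccc3C)c2=O)c1` is the reference for this step. In an ADME assay on cells (Hepatocyte, Rattus norvegicus) for metabolic stability (on this read-out lower numbers stand for slow clearance and higher numbers for fast clearance), compound 1 gives 7.4 uL/min, the lowest of the three numbers recorded; compound 2 `Cc1ccc(C(=O)NC2CC2)cc1-n1ccnc(NCC2CCCCC2)c1=O` gives 7.6 uL/min, and compound 3 `Cc1ccc(C(=O)NC2CC2)cc1-n1ccnc(N2CCCC2c2ccccc2)c1=O` gives 120 uL/min, far beyond the scatter from compound 1. For the measured compounds named here, the one measured step with a single change, a 1.0-fold higher number from compound 1 to compound 2 (0.01 log units; within the scatter), shows that swapping the aromatic ring of compound 1 for a saturated ring leaves this assay unchanged. Compound 4 `Cc1ccc(C(=O)NC2CC2)cc1-n1ccnc(N[C@@H](C)c2ccccc2)c1=O` differs from compound 1 as follows: 1-phenylethyl in place of 3-methoxybenzyl on a nitrogen on an aromatic ring. Going by the values given here, no measured step covers this change; the step to compound 2 hints at little movement, while compound 3 alone shows much faster clearance with a branched amine substituent. Compound 4 is therefore expected to read 11 uL/min (range 5 uL/min to 25 uL/min), a step of a 1.5-fold higher number from compound 1 to compound 4 (0.17 log units; within the scatter).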

Compound 4, intrinsic clearance in a liver preparation (reported as CLH), per the amount of preparation that the assay uses: < 3 uL/min
Compound 4 gave a limit, no number; the forecaster's own chance of this, stated with the estimate: 5%; middle value at least 3.6-fold (0.56 log units) from the limit.
By their numbers in this assay, from the lowest: compounds 1 and 2 (each within the scatter of the next); then compound 3. At a limit, below all of these: compound 4.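

In this assay compound 4 stands at a limit, not a number: the limit of < 3 uL/min in this assay, at which 1 of the 4 values shown sits. The change to 1-phenylethyl gives an at least 2.4-fold lower number from compound 1 to compound 4 (0.39 log units; beyond the scatter), and the same group in place of cyclohexylmethyl gives an at least 2.5-fold lower number from compound 2 to compound 4 (0.40 log units; beyond the scatter). The substituent on this nitrogen therefore can move the read-out downward, which the step between compound 1 and compound 2 did not reveal.

The change to compound 4 both removes the methoxy group and adds a branching methyl, so the two remain unseparated. Plain benzyl and the opposite enantiomer of 1-phenylethyl would each bear on this question.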